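The source may report more compounds than this note shows. Statements on the series, on what has been measured and on what is new or still open speak of the compounds shown alone.

Measured so far in a functional assay on the whole organism (strain CF-1) for positive allosteric modulation, with Mus musculus as the target; a higher number here means that more compound is needed for the effect, a lower number that less compound is needed:
Compound 1, `Cc1nnc(CN(C)C)n1-c1ccc(Cl)cc1C(=O)c1ccccc1`, gives 1.1 mg/kg.
Compound 2, `Cc1nnc(CN2CCCC2)n1-c1ccc(Cl)cc1C(=O)c1ccccc1`, gives 1.8 mg/kg.
Compound 3, `Cc1nnc(CN2CCCC2)n1-c1ccc(Cl)cc1C(=O)c1ccccc1Cl`, gives 6 mg/kg.

Compound 2 holds the second highest of these three numbers. Its nearest neighbour shows a 1.6-fold higher number from compound 1 to compound 2 (0.21 log units; within the scatter); the furthest shows a 3.3-fold higher number from compound 2 to compound 3 (0.52 log units; beyond the scatter). Compound 4, `CCNCc1nnc(C)n1-c1ccc(Cl)cc1C(=O)c1ccccc1`, differs from compound 2 in one place: ethylamino in place of pyrrolidin-1-yl on a saturated chain carbon bound to an aromatic carbon. Among the compounds with values here, only the step from compound 1 to compound 2 touches the same spot, swapping one amine for another, and it stayed within the scatter. Within the data shown here, no measured compound carries an amine with a hydrogen-bond donor, so that part of the change is untested. A step of a 1.2-fold lower number from compound 2 to compound 4 (0.08 log units; within the scatter) is therefore expected, none beyond the scatter. Compound 4 is estimated at 1.5 mg/kg, between 0.6 mg/kg and 4.5 mg/kg.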

Compound 4, dose for half-maximal effect: 0.6 mg/kg
For compound 4 the middle estimate is 2.5-fold (0.40 log units) above the measured one; measured number inside the range.
By their numbers in this assay, from the lowest: compounds 4, 1 and 2 (each within the scatter of the next, the first and the last beyond it); then compound 3.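

In this assay, within the data shown here, this position proves sensitive to the choice of amine: ethylamino in place of pyrrolidin-1-yl gives a 3.0-fold lower number from compound 2 to compound 4 (0.48 log units; beyond the scatter), the first change here to exceed the scatter. Ethylamino in place of dimethylamino gives only a 1.8-fold lower number from compound 1 to compound 4 (0.26 log units; within the scatter), so the two open-chain amines cannot be told apart by this measurement. Nothing available accounts for either step. Still open, from the compounds shown here alone, is how methylamino, a longer chain such as butylamino, or the larger ring amine piperidin-1-yl would compare at this position.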